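This account rests on a few compounds, and the source may have more. Where it says the series, first, only, none or still open, it means among the compounds named here.

This piece follows the step from compound 1, `O=C1N[C@H]2[C@H](CS[C@H]2CCCCCc2cn(Cc3cccc(O)c3)nn2)N1`, to compound 4, `O=C1N[C@H]2[C@H](CS[C@H]2CCCCCc2cn(Cc3ccc(I)cc3)nn2)N1`. In an assay on isolated protein for inhibition of biotin--protein ligase (Homo sapiens), read by scintillation counting, with a stated time of 10 min (a lower number here means a stronger inhibitor, a higher number a weaker inhibitor), compound 1 gives > 16000 nM, which is a limit of the assay rather than a number. Two near relatives are on record. Compound 2, `Nc1ccccc1Cn1cc(CCCCC[C@@H]2SC[C@@H]3NC(=O)N[C@@H]32)nn1`, gives > 16000 nM in this assay, again a limit. Compound 3, `Cc1cccc(Cn2cc(CCCCC[C@@H]3SC[C@@H]4NC(=O)N[C@@H]43)nn2)c1`, gives > 16000 nM in this assay, also a limit. Within the data shown here, the steps among them, a step that the two limits leave unreadable from compound 1 to compound 2, a step that the two limits leave unreadable from compound 1 to compound 3 and a step that the two limits leave unreadable from compound 2 to compound 3, are therefore all unreadable, and the only evidence is the limit of > 16000 nM in this assay, at which 3 of the 3 values shown sit.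

The change to compound 4 is 4-iodophenyl in place of 3-hydroxyphenyl on a saturated chain carbon bound to an aromatic nitrogen. Nothing measured reads on a 4-iodophenyl group here, and the shown steps give no size or direction. The expectation for compound 4 is therefore that it stays near the limit, so the estimated step that the limit leaves unreadable from compound 1 to compound 4 is taken as none beyond the scatter. Compound 4 is expected to give about 20000 nM, with a range from 6000 nM to 80000 nM.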

Compound 4, inhibition constant: > 16000 nM
Compound 4: a limit, no number; the forecaster's own chance of this, stated with the estimate: 70%; the middle value does not contradict the limit.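

In this assay compound 4 gives > 16000 nM, which is a limit and not a number. Its steps from compound 1, compound 2 and compound 3 therefore cannot be read. The compounds shown leave open whether any group in this place gives a measurable value, and the only evidence so far is this: the limit of > 16000 nM in this assay, at which 4 of the 4 values shown sit.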